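The source may hold more compounds than are shown below. What is called first, only, known or untested is meant among the compounds shown, and "the series" means these compounds.

Three compounds built on one shared core were tested in a functional assay on MCF7 cells (Homo sapiens) for antiproliferative activity, read by MTT assay, with a stated time of 72 h; on this read-out higher numbers stand for weaker inhibition and lower numbers for stronger inhibition. Compound 1, with the structure `O=C(COc1ccc(C(=O)/C=C/c2ccccc2Br)cc1)N[C@H]1CCOC1=O`, gives 15300 nM in this assay. Compound 2, `O=C(CNc1ccc(Cl)cc1Cl)N[C@H]1CCOC1=O`, reaches only the limit of the assay, reported as > 64000 nM, so no number is known for it. Compound 3, `O=C1OCC[C@@H]1NC(=S)SCCOc1ccccc1`, likewise gives only the limit, reported as > 64000 nM. For the measured compounds named here, compound 1 therefore stands as the single compound with a measured number, while the remaining two values sit at the limit of > 64000 nM in this assay, at which 2 of the 3 values shown sit.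

Compound 4, `O=C(COc1ccc(C(=O)/C=C/c2ccc(F)cc2)cc1)N[C@H]1CCOC1=O`, has not yet been measured in this assay. It differs from compound 1 in one place: 4-fluorophenyl in place of 2-bromophenyl on a double-bonded chain carbon bound to a double-bonded chain carbon. Going by the values given here, no step between two measured compounds is available to show how much such a change matters here. Both groups carry the same count of heavy atoms, a single halogen on a six-membered aromatic ring of carbon only, and neither adds a hydrogen-bond donor or acceptor, so the step is expected to be modest. The expected step from compound 1 to compound 4 is a 1.4-fold higher number from compound 1 to compound 4 (0.16 log units; within the scatter), leaning slightly toward weaker inhibition but within the scatter. Compound 4 is estimated at 22000 nM, with a likely range from 7000 nM to 64000 nM.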

Compound 4, half-maximal inhibitory concentration: > 64000 nM
Compound 4 ended at the assay's limit; the forecaster's own chance of this, stated with the estimate: 25%; middle value at least 2.9-fold (0.46 log units) from the limit.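

For the compounds shown here, putting 4-fluorophenyl in place of 2-bromophenyl gives the first single-place change that can be read in this assay, and it produces an at least 4.1-fold higher number from compound 1 to compound 4 (0.62 log units; beyond the scatter). As far as these compounds go, the value of compound 4 is a limit and not a number, so the true size of this step stays unknown, yet the step shows that this place on the double-bonded chain is sensitive: two groups with the same count of heavy atoms, each a single halogen on a six-membered aromatic ring of carbon only, are not interchangeable here. Compound 1 stays the only compound with a measured number, and the others now share one ceiling: the limit of > 64000 nM in this assay, at which 3 of the 4 values shown sit.

This one change alters both the halogen and where it sits on the ring, so the compounds shown cannot say which of the two matters, whereas 2-fluorophenyl or 4-bromophenyl would pull the two apart. Also open, from the compounds shown here alone, is how plain phenyl, or a ring carrying an amine or a carboxylic acid, would behave at this place.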